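Three inactive anilinoquinazoline sulfonamides and an unsubstituted phenyl analogue

The compounds below may be only part of what the source reports. "The series", "measured", "known", "first", "only" and "open" are said of these compounds alone.

Compound 1: `COc1cc2ncnc(Nc3ccc(Br)cc3)c2cc1OCCCCC(=O)Nc1ccc(S(N)(=O)=O)cc1` — > 40000 nM
Compound 2: `COc1ccc(Nc2ncnc3cc(OC)c(OCCCCC(=O)Nc4ccc(S(N)(=O)=O)cc4)cc23)cc1OC` — > 40000 nM
Compound 3: `COc1cc2ncnc(Nc3cc(F)c(F)c(F)c3)c2cc1OCCCCC(=O)Nc1ccc(S(N)(=O)=O)cc1` — > 40000 nM

The three measured compounds share a core that carries a substituted phenyl on a nitrogen on an aromatic ring and a chain ending in a sulfonamide-bearing anilide. In a functional assay on A549 cells (Homo sapiens) for antiproliferative activity, read by MTT assay, with a stated time of 72 h (on this read-out lower numbers stand for stronger inhibition and higher numbers for weaker inhibition), compound 1 gives > 40000 nM, which is a limit of the assay and not a number. In this assay compound 2 likewise gives > 40000 nM, again a limit. In this assay compound 3 gives > 40000 nM, also a limit. Compound 2 therefore stands at the limit of > 40000 nM in this assay, at which 3 of the 3 values shown sit, alongside the two others.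

The steps among them, a step that the two limits leave unreadable from compound 1 to compound 2, a step that the two limits leave unreadable from compound 1 to compound 3 and a step that the two limits leave unreadable from compound 2 to compound 3, cannot be sized, because every value sits at the limit of > 40000 nM in this assay, at which 3 of the 3 values shown sit.

Compound 4, `COc1cc2ncnc(Nc3ccccc3)c2cc1OCCCCC(=O)Nc1ccc(S(N)(=O)=O)cc1`, is not yet measured. It differs from compound 2 by phenyl in place of 3,4-dimethoxyphenyl on a nitrogen on an aromatic ring. The measured steps that bear on this change all concern the group on that nitrogen, and none of them gives a readable size. The expectation for compound 4 is therefore that a number no higher from compound 2 to compound 4 (the limit leaves the size open) stays unreadable and that the assay again returns a limit. Compound 4 is estimated at 40000 nM, with a range from 15000 nM to 120000 nM.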

Compound 4, half-maximal inhibitory concentration: > 40000 nM
Compound 4 gave a limit, no number (the forecaster's own chance of this, stated with the estimate: 80%); the middle value lies on the limit itself.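

In this assay compound 4 gives > 40000 nM as a limit of the assay and not a number. Among the compounds shown here, compounds 1, 2, 3 and 4 all sit at this same limit, so no step among them can be read. The compounds shown leave open whether any group on that nitrogen would give a readable value in this assay at all.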